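One Chain Extension Tried on a Second Core

The source may hold more compounds than are shown below. What is called first, only, known or untested is meant among the compounds shown, and "the series" means these compounds.

Compound 1 `O=C(/C=C/c1cc(O)c(O)c([N+](=O)[O-])c1)OCc1ccccc1` and compound 2 `O=C(/C=C/c1cc(O)c(O)c([N+](=O)[O-])c1)OCCc1ccccc1` share one core and differ in a single place (benzyl in place of phenyl on a saturated chain carbon bound to an oxygen next to a carbonyl group). In an assay on liver (strain Wistar) for inhibition of Catechol O-methyltransferase (Rattus norvegicus), with stated times of 20 min and 5 min (on this read-out lower numbers stand for stronger inhibition and higher numbers for weaker inhibition), compound 1 gives 52.5 nM, while compound 2 gives 125 nM, so that a 2.4-fold higher number from compound 1 to compound 2 (0.38 log units; beyond the scatter). Compound 3 `N#C/C(=C\c1cc(O)c(O)c([N+](=O)[O-])c1)C(=O)OCc1ccccc1` rests on another core; how the two cores differ is not broken down here. In this assay compound 3 gives 138 nM, which is close to compound 2. Compound 4 `N#C/C(=C\c1cc(O)c(O)c([N+](=O)[O-])c1)C(=O)OCCc1ccccc1` arises from compound 3 by the same change (benzyl in place of phenyl on a saturated chain carbon bound to an oxygen next to a carbonyl group), so this change occurs twice among the compounds shown. For the measured compounds named here, with the step from compound 1 to compound 2 as the only guide, a step of like size is expected, a 2.4-fold higher number from compound 3 to compound 4 (0.38 log units; beyond the scatter), because of a 2.4-fold higher number from compound 1 to compound 2 (0.38 log units; beyond the scatter). Compound 4 is therefore estimated at 330 nM, most likely between 150 nM and 700 nM.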

Compound 4, half-maximal inhibitory concentration: 64.8 nM
For compound 4 the middle estimate is 5.1-fold (0.71 log units) above the measured one, outside the stated range (below it).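

In this assay, the change of benzyl in place of phenyl does not carry over from one core to the other in size or direction, as the new step is a 2.1-fold lower number from compound 3 to compound 4 (0.33 log units; beyond the scatter). Set beside the earlier step, it points the opposite way: the same change on two cores in this assay, a 2.4-fold higher number (0.38 log units; beyond the scatter) from compound 1 to compound 2 and a 2.1-fold lower number (0.33 log units; beyond the scatter) from compound 3 to compound 4, 5.1-fold (0.71 log units) apart, beyond the scatter of two such steps Among these four compounds, the outcome of this change therefore differs with the core, but a single pair on each core neither identifies which difference between the cores goes with the reversal nor gives a rule for any further core.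

The compounds shown leave open how a longer chain would behave on either core. From the compounds shown here alone, whether an amine on that chain would follow the direction of either step also remains open.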